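The source may report more compounds than this note shows. Statements on the series, on what has been measured and on what is new or still open speak of the compounds shown alone.

Measured so far in a functional assay on HeLa cells (Homo sapiens) for inhibition, read by sulforhodamine B assay, with a stated time of 48 h; on this read-out lower numbers stand for stronger inhibition of growth and higher numbers for weaker inhibition of growth:

Compound 1, `O=C(/C=C/c1ccccc1)OCC1COCCOCCOCCOCCOCCO1`, gives 48000 nM.
Compound 2, `O=C(CCCCCc1ccccc1)OCC1COCCOCCOCCOCCOCCO1`, gives 79000 nM.
Compound 3, `CC/C=C/CC(=O)OCC1COCCOCCOCCOCCOCCO1`, gives > 100000 nM, which is a limit of the assay and not a number.

Compound 3 thus sits at the limit of > 100000 nM in this assay, at which 1 of the 3 values shown sits, and only a range is known for it. Compound 4, `CC(=O)OCC1COCCOCCOCCOCCOCCO1`, differs from compound 3 by hydrogen in place of but-1-en-1-yl on a saturated chain carbon bound to a carbonyl carbon. The measured steps that touch the chain on the carbonyl side are an at least 1.2-fold higher number from compound 2 to compound 3 (0.10 log units; that floor lies within the scatter) and an at least 2.0-fold higher number from compound 1 to compound 3 (0.31 log units; beyond the scatter), both moving toward weaker inhibition of growth, so a still shorter chain is not expected to bring any gain. Compound 4 is expected to give about 150000 nM, with a range from 60000 nM to 400000 nM, most likely reported again only as a limit. The expected step that the limit leaves unreadable from compound 3 to compound 4 is none beyond the scatter.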

Compound 4, concentration for 50% growth inhibition: > 100000 nM
Compound 4 gave a limit, no number (the forecaster's own chance of this, stated with the estimate: 80%); the middle value does not contradict the limit.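

In this assay compound 4 gives > 100000 nM, which is a limit, so shortening the chain to the acetyl group leaves it at the limit with compound 3, and the step between these two cannot be read. Against the compounds that carry a phenyl ring, the data show an at least 2.0-fold higher number from compound 1 to compound 4 (0.31 log units; beyond the scatter), and an at least 1.2-fold higher number from compound 2 to compound 4 (0.10 log units; that floor lies within the scatter). Among these four compounds, only the two with a phenyl ring give numbers, while the two without one do not: the limit of > 100000 nM in this assay, at which 2 of the 4 values shown sit.

On these data alone, the true values of compound 3 and compound 4 stay unknown. As far as these compounds go, whether a pyridine ring in place of the phenyl ring, or an amine at the end of the chain, would give a readable value also remains open.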